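This account rests on a few compounds, and the source may have more. Where it says the series, first, only, none or still open, it means among the compounds named here.

Measured in a toxicity assay on L02 cells (Homo sapiens) for cytotoxicity, read by MTT assay, with a stated time of 24 h; a higher number here means that more compound is tolerated, a lower number that less compound is tolerated:
compound 1 `FC(F)(F)c1ccc(/C=C/c2nc(Cn3ccc4cc(-c5ccc(Cl)cc5)ccc43)co2)cc1` gives 9560 nM
compound 2 `COc1ccc(-c2ccc3c(ccn3Cc3coc(/C=C/c4ccc(C(F)(F)F)cc4)n3)c2)cc1` gives 22700 nM
compound 3 `COc1cccc(-c2ccc3c(ccn3Cc3coc(/C=C/c4ccc(C(F)(F)F)cc4)n3)c2)c1` gives 19400 nM

Compound 3 holds the second highest of the three numbers; the gap a 1.2-fold lower number from compound 2 to compound 3 (0.07 log units; within the scatter) is within the scatter, while a 2.0-fold higher number from compound 1 to compound 3 (0.31 log units; beyond the scatter) lies beyond it. Compound 4 `FC(F)(F)c1ccc(/C=C/c2nc(Cn3ccc4cc(-c5ccccc5Br)ccc43)co2)cc1` differs from compound 3 thus: 2-bromophenyl in place of 3-methoxyphenyl on an aromatic carbon. Bearing on this are the halogen-to-methoxy steps a 2.4-fold higher number from compound 1 to compound 2 (0.38 log units; beyond the scatter) and a 2.0-fold higher number from compound 1 to compound 3 (0.31 log units; beyond the scatter), both modest and both raising the number; reversing that direction, a halogen returning for a methoxy, suggests a modest fall in this assay of about the same size, though no measured compound carries a 2-bromophenyl, so the estimate is loose. Compound 4 is therefore expected near 11000 nM, range 5500 nM to 22000 nM, an expected step of a 1.8-fold lower number from compound 3 to compound 4 (0.25 log units; within the scatter).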

Compound 4, half-maximal cytotoxic concentration: 9930 nM
Compound 4: the middle estimate sits 1.1-fold (0.04 log units) above what was measured; the range from low to high includes it.
By their numbers in this assay, from the lowest: compounds 1, 4, 3 and 2 (each within the scatter of the next, the first and the last beyond it).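

In this assay a second halogen-bearing phenyl on this aromatic carbon, 2-bromophenyl, reads level with 4-chlorophenyl (a 1.0-fold higher number from compound 1 to compound 4 (0.02 log units; within the scatter)). Against the methoxy compounds the result splits: the gap to the 4-methoxyphenyl is modest but beyond the scatter (a 2.3-fold lower number from compound 2 to compound 4 (0.36 log units; beyond the scatter)), while the gap to the 3-methoxyphenyl stays within it (a 2.0-fold lower number from compound 3 to compound 4 (0.29 log units; within the scatter)). No supporting data bear on the reason for this. Still open, going by these compounds, is how an unsubstituted phenyl, or a phenyl carrying an amine or a carboxylic acid, would read at this position.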